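The compounds below may be only part of what the source reports. "The series", "measured", "known", "first", "only" and "open" are said of these compounds alone.

Compound 1 `COC(=O)c1cn(C/C=C(/C)CC/C=C(\C)CCC=C(C)C)nn1` gives 5.25 in a physicochemical assay for lipophilicity, measured as octanol-water partition; on this read-out lower numbers stand for lower lipophilicity and higher numbers for higher lipophilicity. Compound 3 `COC(=O)c1cn(C/C=C(\C)CC/C=C(\C)CCC=C(C)C)nn1` gives 5.25 in this assay. no change at the digits printed from compound 1 to compound 3 (within the scatter), consistent with the fact that compounds 1 and 3 differ only in the configuration as drawn. Compound 2 `COC(=O)c1cn(C/C=C(/C)CCC=C(C)C)nn1` gives 3.2. a number 2.05 log units lower from compound 1 to compound 2 (beyond the scatter). Compound 1 therefore stands level with compound 3 at the digits shown, the pair together the highest of the three numbers, with compound 2 the furthest below. Compound 4 `CCCCCCCCc1cn(C/C=C(/C)CC/C=C(\C)CCC=C(C)C)nn1` carries a different change: octyl in place of methoxycarbonyl on an aromatic carbon. Going by the values given here, no measured pair swaps these two groups, so only the chain-length step gives a scale: that step was large, and here an octyl chain enters where a methoxycarbonyl leaves, so a large rise is expected, a number 3.15 log units higher from compound 1 to compound 4 (beyond the scatter). Compound 4 is estimated at 8.4, between 7.3 and 9.5.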

Compound 4, partition coefficient: 8.76
Estimate against measurement, compound 4: 0.36 log units below; measured number inside the range.
By their numbers in this assay, from the lowest: compound 2; then compounds 1 and 3 (each within the scatter of the next); then compound 4.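

Octyl in place of methoxycarbonyl on an aromatic carbon gives a number 3.51 log units higher from compound 1 to compound 4 (beyond the scatter), the first reading of this position in this assay. The earlier steps shown here touched only the chain and the configuration of one double bond, while methoxycarbonyl stayed in place. Nothing on hand accounts for the size of this step.

Open, going by these compounds, is how the number runs with a butyl chain or a carboxylic acid on this aromatic carbon. Also open, on these data alone, is whether octyl gives a similar step on the shorter chain of compound 2.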